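Swapping trifluoromethyl for fluoro on the aromatic ring

The source may hold more compounds than are shown below. What is called first, only, known or untested is meant among the compounds shown, and "the series" means these compounds.

Compound 1 `C=C1C(=O)[C@@]23C(=O)OC[C@]4(C(=O)CCC(C)(C)[C@H]4C=O)[C@@H]2CC[C@@H]1[C@H]3OC(=O)c1ccc(OC)cc1` gives 2980 nM
Compound 2 `C=C1C(=O)[C@@]23C(=O)OC[C@]4(C(=O)CCC(C)(C)[C@H]4C=O)[C@@H]2CC[C@@H]1[C@H]3OC(=O)c1ccc(C(F)(F)F)cc1` gives 8960 nM

In a functional assay on CaEs17 cells (Homo sapiens) for cytotoxicity, read by MTT assay, with a stated time of 72 h (on this read-out lower numbers stand for stronger inhibition and higher numbers for weaker inhibition), compound 2 stands highest at 8960 nM and is the weaker of the pair. Compound 3 `C=C1C(=O)[C@@]23C(=O)OC[C@]4(C(=O)CCC(C)(C)[C@H]4C=O)[C@@H]2CC[C@@H]1[C@H]3OC(=O)c1ccc(F)cc1` has fluoro in place of trifluoromethyl on an aromatic carbon, para to a large group, and fluoro in place of trifluoromethyl on an aromatic carbon counts the exchange. Among the measured compounds shown here, the one measured step at this place is a 3.0-fold higher number from compound 1 to compound 2 (0.48 log units; beyond the scatter) and it is modest. For the measured compounds named here, only that step guides the estimate, so a similarly modest move toward a lower number is expected, possibly within the scatter. An expected 1.9-fold lower number from compound 2 to compound 3 (0.27 log units; within the scatter) is the estimate. For compound 3 an estimated 4800 nM is expected, with 2200 nM to 10000 nM as the likely span.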

Compound 3, half-maximal inhibitory concentration: 8310 nM
Beside the measured number, compound 3's estimate is 1.7-fold (0.24 log units) below it, within the range that was stated.
By their numbers in this assay, from the lowest: compound 1; then compounds 3 and 2 (each within the scatter of the next).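

Exchanging trifluoromethyl for fluoro on this aromatic carbon, para to a large group, gives a 1.1-fold lower number from compound 2 to compound 3 (0.03 log units; within the scatter). The two groups therefore cannot be told apart in this assay, although fluoro has fewer heavy atoms, whereas methoxy stays set apart, with a 2.8-fold higher number from compound 1 to compound 3 (0.45 log units; beyond the scatter). Nothing available explains why methoxy separates from the other two.

As far as these compounds go, it remains open whether an amine, a hydroxyl or a carboxylic acid at this place would fall nearer methoxy or nearer the two fluorine-bearing groups. From the compounds shown here alone, whether a longer chain such as ethoxy would keep the methoxy level is also open.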